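The source may report more compounds than this note shows. Statements on the series, on what has been measured and on what is new or still open speak of the compounds shown alone.

In a functional assay on HeLa cells (Homo sapiens) for antiproliferative activity, read by MTT assay, with a stated time of 48 h (a higher number here means a weaker inhibitor, a lower number a stronger inhibitor), compound 1 `Fc1ccc(-c2nn(-c3ccccc3)cc2-c2nc3cc(Cl)ccc3[nH]2)cc1` gives 2770 nM and compound 2 `Fc1ccc2[nH]c(-c3cn(-c4ccccc4)nc3-c3ccc(Cl)cc3)nc2c1` gives 2770 nM as well, so compound 2 stands level with compound 1. Compound 3 `Clc1ccc(-c2nn(-c3ccccc3)cc2-c2nc3cc(Cl)ccc3[nH]2)cc1` is still unmeasured and differs from compound 2 by chloro in place of fluoro on an aromatic carbon. Within the data shown here, no measured pair shows this swap, so the expectation starts from compound 2 at 2770 nM and is for no change beyond the scatter of repeat measurements. The estimated step of a 1.0-fold lower number from compound 2 to compound 3 (0.01 log units; within the scatter) stays within that scatter. For compound 3 the estimated value is 2700 nM with an expected range from 1300 nM to 5500 nM in this test.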

Compound 3, half-maximal inhibitory concentration: 1630 nM
Compound 3: middle estimate off by 1.7-fold (0.22 log units), on the high side; measured number inside the range.
By their numbers in this assay, from the lowest: compounds 3, 1 and 2 (each within the scatter of the next).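

Chloro in place of fluoro on the fused pair of rings gives a 1.7-fold lower number from compound 2 to compound 3 (0.23 log units; within the scatter), and the same swap at the other halogen-bearing place in the shared core gives a 1.7-fold lower number from compound 1 to compound 3 (0.23 log units; within the scatter), so at both places this change stays within the scatter of repeat measurements. No further data here bear on these two steps. From the compounds shown here alone, what stays open is whether a group other than these two halogens, such as an amine or a carboxylic acid, would shift the number beyond that scatter at either place.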